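The source may hold more compounds than are shown below. What is called first, only, known or untested is meant among the compounds shown, and "the series" means these compounds.

Series notes on the melanin-concentrating hormone receptor 1 set

Compound 1 `CCCc1cc(NC)c2cc(NC(=O)/C=C/c3ccc(C(F)(F)F)cc3)ccc2n1` is the reference point here. In an assay on isolated protein for displacement of a labelled ligand from melanin-concentrating hormone receptor 1 (Homo sapiens) (on this read-out higher numbers stand for weaker inhibition and lower numbers for stronger inhibition), compound 1 gives 1.5 nM. For the measured compounds named here, compound 3 `CCc1cc(N)c2cc(NC(=O)/C=C/c3ccc(C(F)(F)F)cc3)ccc2n1`, carrying an ethyl group and an amino group on the shared core, gives 1.2 nM in this assay, a number within the scatter of the one for compound 1, so nothing separates the two. Compound 2 `CCCc1cc(N)c2cc(NC(=O)/C=C/c3ccc(Cl)cc3)ccc2n1`, with an amino group on the core and a chloro substituent on the cinnamoyl ring, gives 6 nM in this assay, which puts compound 1 well on the stronger side of compound 2 and beyond the scatter. Among the three measured numbers compound 1 thus sits second highest, close to compound 3 and clearly apart from compound 2. Going by the values given here, no single-change comparison between measured compounds is available, so there is no measured step to lean on.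

Compound 4 `CCCc1cc(N2CCCCC2)c2cc(NC(=O)/C=C/c3ccc(C(F)(F)F)cc3)ccc2n1` is not yet measured. It differs from compound 1 as follows: piperidin-1-yl in place of methylamino on an aromatic carbon. The aromatic carbon involved is the one ortho to a fused ring and opposite the ring nitrogen. The measured compounds hold only amino or methylamino at this carbon. Among the compounds with values here, no measured compound carries a six-membered non-aromatic ring at this carbon, so nothing measured speaks to that change. The expectation, stated as a guess, is a step from compound 1 to compound 4 of a 3.3-fold higher number from compound 1 to compound 4 (0.52 log units; beyond the scatter), a weakening somewhat beyond the scatter. Compound 4 is therefore estimated at 5 nM, with a range from 1.5 nM to 20 nM.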

Compound 4, half-maximal inhibitory concentration: > 4000 nM
Compound 4: only a limit was reported; the forecaster's own chance of this, stated with the estimate: 3%; at least 800-fold (2.90 log units) between middle value and limit.
By their numbers in this assay, from the lowest: compounds 3 and 1 (each within the scatter of the next); then compound 2. At a limit, above all of these: compound 4.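

Compound 4 gives > 4000 nM in this assay, and this is a limit of the assay, not a number. For the compounds shown here, the earlier compounds held only amino or methylamino at the aromatic carbon opposite the ring nitrogen, so they could not show how far this position tolerates change; piperidin-1-yl in place of methylamino now gives an at least 2600-fold higher number from compound 1 to compound 4 (3.42 log units; beyond the scatter), the one large step, which shows that this carbon does not accept every amine substituent without a heavy loss of inhibition. The step can be read only as a minimum, because the value of compound 4 stops at a limit: the limit of > 4000 nM in this assay, at which 1 of the 4 values shown sits.

The change brings in a ring, more heavy atoms and the loss of the hydrogen-bond donor all at once, and the compounds shown leave open which of these goes with the loss. Ethylamino, which keeps the donor and has no ring, dimethylamino, which has neither donor nor ring, and a smaller cyclic amine such as pyrrolidin-1-yl at this carbon would pull these apart.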